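This account rests on a few compounds, and the source may have more. Where it says the series, first, only, none or still open, it means among the compounds named here.

Compounds measured so far:
compound 1 `Cn1c(-c2ccc(NC(=O)CCl)cc2)nc(-c2ccccc2)c1-c1ccccc1` — 42.8%
compound 2 `Cn1c(-c2ccc(NC(=O)CSc3nc4ccccc4s3)cc2)nc(-c2ccccc2)c1-c1ccccc1` — 59%
compound 3 `CN1CCN(CC(=O)Nc2ccc(-c3nc(-c4ccccc4)c(-c4ccccc4)n3C)cc2)CC1` — 46.2%

In a functional assay on MCF7 cells (Homo sapiens) for cytotoxicity, read by MTT assay, with a stated time of 24 h, tested at 32 ug/mL (on this read-out lower numbers stand for a weaker effect and higher numbers for a stronger effect at the one concentration tested), compound 3 gives 46.2%, the second highest of the three numbers. Its gap to compound 1, a number 3.4 percentage points higher from compound 1 to compound 3 (within the scatter), lies within the scatter, while its gap to compound 2, a number 12.8 percentage points lower from compound 2 to compound 3 (beyond the scatter), lies beyond it. Compound 4 `COc1ccc(CN2CCN(CC(=O)Nc3ccc(-c4nc(-c5ccccc5)c(-c5ccccc5)n4C)cc3)CC2)cc1` is not yet measured. It differs from compound 3 only in this: 4-methoxyphenyl in place of hydrogen on a saturated chain carbon bound to an amine nitrogen in a ring.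

For the measured compounds named here, none of the measured steps touches this place; all three vary the group on a saturated chain carbon bound to a carbonyl carbon. Going by the values given here, the only guide is that the one step adding an aromatic ring, a number 16.2 percentage points higher from compound 1 to compound 2 (beyond the scatter), was a modest rise, whereas the step adding the 4-methylpiperazin-1-yl group, a number 3.4 percentage points higher from compound 1 to compound 3 (within the scatter), stayed within the scatter. The step from compound 3 to compound 4 is therefore expected to be small, at most a modest rise, a number 5.8 percentage points higher from compound 3 to compound 4 (within the scatter). Compound 4 is expected to give about 52%, in the range 35% to 68%.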

Compound 4, a percentage reported as activity, at one concentration (the size of the read-out at that concentration, not a potency): 17.7%
Compound 4: middle estimate off by 34.3 percentage points, on the high side; the whole stated range lies above it.
By their numbers in this assay, from the lowest: compound 4; then compounds 1 and 3 (each within the scatter of the next); then compound 2.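

In this assay, replacing the methyl with 4-methoxybenzyl, which adds a 4-methoxyphenyl on a saturated chain carbon bound to an amine nitrogen in a ring, gives a number 28.5 percentage points lower from compound 3 to compound 4 (beyond the scatter). For the compounds shown here, this shows that the read-out responds to a change at this outer place, which none of the earlier steps touched, and that adding an aromatic ring need not raise the number, as it did at the other place in a number 16.2 percentage points higher from compound 1 to compound 2 (beyond the scatter). Nothing measured here explains the fall.

The compounds shown leave open whether the fall follows from the aromatic ring itself or from its methoxy group, which a plain benzyl group could help separate. They also leave open how a small chain such as ethyl would behave at this place.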